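The source may report more compounds than this note shows. Statements on the series, on what has been measured and on what is new or still open speak of the compounds shown alone.

The measured compounds:
- compound 1, `c1cncc(-c2ccccc2OCC2=NCCN2)c1`: in a functional assay for activation of Alpha-1B adrenergic receptor (Homo sapiens), read by calcium flux (on this read-out lower numbers stand for an effect already at smaller amounts and higher numbers for an effect only at larger amounts of compound), compound 1 gives 79.4 nM.
- compound 2, `c1ccc(-c2ccncn2)c(OCC2=NCCN2)c1`: in this assay compound 2 gives only a limit of the assay, < 100000 nM.
- compound 3, `c1ccc(-c2ncc[nH]2)c(OCC2=NCCN2)c1`: in this assay compound 3 also gives only a limit of the assay, < 100000 nM.

Compound 2 therefore stands on a limit rather than on a number, and of the three values shown two sit at that limit (the limit of < 100000 nM in this assay, at which 2 of the 3 values shown sit). The step that the limit leaves unreadable from compound 1 to compound 2, the step that the limit leaves unreadable from compound 1 to compound 3 and the step that the two limits leave unreadable from compound 2 to compound 3 are all unreadable in size for that reason.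

Compound 4, `Cc1ccc(-c2ccccc2OCC2=NCCN2)s1`, has not yet been measured. It differs from compound 2 in one place: 5-methylthiophen-2-yl in place of pyrimidin-4-yl on an aromatic carbon.

For the measured compounds named here, none of the measured steps gives a readable size, so none bears on this change with a number; the only firm number is that of compound 1 in this assay. Taking compound 1 as the anchor for a compound of this kind, compound 4 is expected to reach a similar potency, an estimated 60 nM, within 8 nM to 500 nM. The step this estimate implies, a step that the limit leaves unreadable from compound 2 to compound 4, is expected to run toward smaller amounts, though its size against a limit cannot be stated.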

Compound 4, half-maximal effective concentration: < 100000 nM
Compound 4: only a limit was reported (the forecaster's own chance of this, stated with the estimate: 15%); the middle value lies beyond the limit too.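

Compound 4 gives only a limit of the assay (< 100000 nM), so its steps from compound 1, compound 2 and compound 3 cannot be read in size, because the values rest on a shared limit: the limit of < 100000 nM in this assay, at which 3 of the 4 values shown sit. The compounds shown leave open how far compound 2, compound 3 and compound 4 truly lie from compound 1, and whether they differ from one another at all.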